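A Fluorine Added Beside a Ring Hydroxy Group

This account rests on a few compounds, and the source may have more. Where it says the series, first, only, none or still open, it means among the compounds named here.

Of the compounds shown here, two with a shared core have been measured. Compound 1 `C/C=C/C(=O)OCC1=CC(O)CCC1=O` and compound 2 `C/C=C/C(=O)OCC1=C[C@@H](O)[C@H](O)CC1=O` were tested in a functional assay on A549 cells (Homo sapiens) for cytotoxicity, read by MTT assay (on this read-out higher numbers stand for weaker inhibition and lower numbers for stronger inhibition), where compound 1 gives 24000 nM and compound 2 gives 147000 nM, the higher of the two numbers. Compound 3 `C/C=C/C(=O)OCC1=C[C@@H](O)[C@H](O)[C@H](F)C1=O` differs from compound 2 by fluoro in place of hydrogen on a saturated ring carbon. Among the compounds with values here, no measured pair shows this change, so its effect is unknown; a small move toward lower numbers, near the edge of the scatter, is expected. The change is expected to give a 2.1-fold lower number from compound 2 to compound 3 (0.32 log units; beyond the scatter). Compound 3 is estimated at 70000 nM, within a range of 20000 nM to 250000 nM.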

Compound 3, half-maximal inhibitory concentration: 164000 nM
Compound 3: middle estimate off by 2.3-fold (0.37 log units), on the low side; the range from low to high includes it.
By their numbers in this assay, from the lowest: compound 1; then compounds 2 and 3 (each within the scatter of the next).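

In this assay, fluoro in place of hydrogen on this saturated ring carbon, next to the ring atom that bears a hydroxy group, gives a 1.1-fold higher number from compound 2 to compound 3 (0.05 log units; within the scatter), so the two compounds cannot be told apart. At this position, then, this single swap produces no readable change in the number. Nothing measured on these compounds accounts for this result. On these data alone, whether an amine or a longer chain on this same carbon would shift the number remains open, as does the effect of fluoro at other ring positions.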